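Nitrogen substituent variation in the 5-alpha-reductase inhibitor series

The source may report more compounds than this note shows. Statements on the series, on what has been measured and on what is new or still open speak of the compounds shown alone.

Measured compounds:
compound 1 `C/C(=C\C(=O)Nc1ccccc1OCCCC(=O)O)c1ccc2c(ccn2C)c1` — 780 nM
compound 2 `CCCCCCn1ccc2cc(/C(C)=C/C(=O)Nc3ccccc3OCCCC(=O)O)ccc21` — 77 nM
compound 3 `C/C(=C\C(=O)Nc1ccccc1OCCCC(=O)O)c1ccc2c(ccn2Cc2ccc(C)cc2)c1` — 88 nM

All three share one core and differ only at the nitrogen of the five-membered ring. In an assay on Prostate gland for inhibition of steroid 5-alpha-reductase (Rattus norvegicus) (on this read-out higher numbers stand for weaker inhibition and lower numbers for stronger inhibition), compound 1, carrying hydrogen there, gives 780 nM. Compound 2 stands lowest of the three numbers; its nearest neighbour is compound 3 and the gap between them is within the scatter, while the step of a 10-fold lower number from compound 1 to compound 2 (1.01 log units; beyond the scatter) is large and beyond the scatter. The parallel step an 8.9-fold lower number from compound 1 to compound 3 (0.95 log units; beyond the scatter) is of similar size, and a 1.1-fold higher number from compound 2 to compound 3 (0.06 log units; within the scatter) shows that pentyl and 4-methylphenyl on that chain carbon give numbers that cannot be told apart.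

Compound 4 `CCCCC(c1ccccc1)n1ccc2cc(/C(C)=C/C(=O)Nc3ccccc3OCCCC(=O)O)ccc21` is not yet measured. Its change from compound 2 is 1-phenylpentyl in place of hexyl on an aromatic nitrogen. Among the compounds with values here, the steps that bear on it are the two from compound 1, which show that any substituent here lowers the number, and the step from compound 2 to compound 3, which shows that the kind of substituent made no difference beyond the scatter. The expectation for this assay is therefore no step beyond the scatter, a 1.2-fold higher number from compound 2 to compound 4 (0.07 log units; within the scatter). Compound 4 is estimated at 90 nM, with a range from 30 nM to 270 nM.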

Compound 4, half-maximal inhibitory concentration: 9.8 nM
Beside the measured number, compound 4's estimate is 9.2-fold (0.96 log units) above it; measured number below the stated range.
By their numbers in this assay, from the lowest: compound 4; then compounds 2 and 3 (each within the scatter of the next); then compound 1.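

In this assay, the identity of the substituent on the aromatic nitrogen matters beyond the scatter after all, since 1-phenylpentyl in place of hexyl gives a clear drop (a 7.9-fold lower number from compound 2 to compound 4 (0.90 log units; beyond the scatter)), and 1-phenylpentyl in place of 4-methylbenzyl gives one of much the same size (a 9.0-fold lower number from compound 3 to compound 4 (0.95 log units; beyond the scatter)). The agreement between hexyl and 4-methylbenzyl therefore did not mark a limit for this position, and 1-phenylpentyl, which holds a phenyl ring and a chain in one substituent, extends the full span of the series (an 80-fold lower number from compound 1 to compound 4 (1.90 log units; beyond the scatter)), leaving compound 4 lowest of the four, with its steps to all the others beyond the scatter. Nothing at hand explains why this substituent gives the lower number.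

The compounds shown do not separate the contribution of the phenyl ring from that of the chain on the carbon bound to the aromatic nitrogen, so 1-phenylethyl, 1-phenylpropyl or a longer 1-phenylheptyl would each test how much of the chain is needed. Going by these compounds, how far the position tolerates a heteroatom also stays open, as a hydroxyl or an amine on that chain, or a pyridine ring in place of the phenyl ring, would show.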